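The source may hold more compounds than are shown below. What is called first, only, known or untested is meant among the compounds shown, and "the series" means these compounds.

The measured compounds:

Compound 1, `COC(=O)CC/C(C)=C/Cc1c(OC)c(C)c2c(c1OCC#CCN1CCN(C(c3ccccc3)c3ccccc3)CC1)C(=O)OC2`, in a functional assay on HT-29 cells (Homo sapiens) for inhibition, read by sulforhodamine B assay; a lower number here means a stronger inhibitor, a higher number a weaker inhibitor: > 50000 nM
Compound 2, `COC(=O)CC/C(C)=C/Cc1c(OC)c(C)c2c(c1OCC#CCN1CCN(C(=O)C3COc4ccccc4O3)CC1)C(=O)OC2`, in this assay: > 50000 nM
Compound 3, `COC(=O)CC/C(C)=C/Cc1c(OC)c(C)c2c(c1OCC#CCN1CCC(Cc3ccccc3)CC1)C(=O)OC2`, in this assay: > 50000 nM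

Each of these values is a limit of this assay rather than a number. Compound 1 reaches only the limit > 50000 nM. Compound 2 likewise reaches only the limit > 50000 nM. Compound 3, too, reaches only the limit > 50000 nM. Going by the values given here, compound 2 therefore stands where every other measured compound stands, since (the limit of > 50000 nM in this assay, at which 3 of the 3 values shown sit); no compound here can be called stronger or weaker than another, and no step between measured compounds is available.

The unmeasured compound is compound 4, `COC(=O)CC/C(C)=C/Cc1c(OC)c(C)c2c(c1OCC#CCN1CCN(Cc3ccc(Cl)cc3)CC1)C(=O)OC2`. It differs from compound 2 in one place: 4-chlorobenzyl in place of (2,3-dihydro-1,4-benzodioxin-2-yl)carbonyl on an amine nitrogen in a ring. Compound 1 and compound 3 already carry aromatic carbon-only groups on the ring amine and both sit at the limit, so the step from compound 2 to compound 4 is expected to be none beyond the scatter in this assay, which is what a number no higher from compound 2 to compound 4 (the limit leaves the size open) means here. Compound 4 is expected to return only a limit again, estimated around 50000 nM, within a range from 20000 nM to 120000 nM.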

Compound 4, half-maximal inhibitory concentration: > 50000 nM
Compound 4 ended at the assay's limit (the forecaster's own chance of this, stated with the estimate: 80%); the middle value sits exactly at the limit.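

No new step can be read between compound 2 and compound 4, whose values in this assay are both limits: the limit of > 50000 nM in this assay, at which 4 of the 4 values shown sit.

The compounds shown leave open whether any group on the ring amine of the shared core gives a readable value in this assay, and how compound 1, compound 2, compound 3 and compound 4 rank against one another.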